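This account rests on a few compounds, and the source may have more. Where it says the series, first, only, none or still open, it means among the compounds named here.

Measured so far:
compound 1 `CC#C[C@H]1CN(S(=O)(=O)c2ccc(N)nc2)CCN1c1ccccc1` — > 399 mL.min-1.g-1
compound 2 `CC#C[C@H]1CN(S(=O)(=O)c2ccc(N)nc2)CCN1c1ccc(S(=N)(=O)C2CC2)cc1` — 23 mL.min-1.g-1

In an ADME assay (liver) for metabolic stability, with Liver microsome (Rattus norvegicus) as the target, using microsomes and NADPH, with a stated time of 30 min (a higher number here means faster removal of the compound, a lower number slower removal), compound 1 gives > 399 mL.min-1.g-1, which is a limit of the assay rather than a number. In this assay compound 2 gives 23 mL.min-1.g-1.

Compound 3 `CC#C[C@H]1CN(S(=O)(=O)c2ccc(N)nc2)CCN1c1ccc(S(N)(=O)=O)cc1` differs from compound 1 by sulfamoyl in place of hydrogen on an aromatic carbon. Among the compounds with values here, the only measured step that bears on this, an at least 17-fold lower number from compound 1 to compound 2 (1.23 log units; beyond the scatter), also replaced a hydrogen atom on an aromatic carbon of the same core and was large. A change in the same direction, and of similar size, is therefore expected: an at least 9.9-fold lower number from compound 1 to compound 3 (0.99 log units; beyond the scatter). Compound 3 is estimated at 40 mL.min-1.g-1, with a likely range from 10 mL.min-1.g-1 to 160 mL.min-1.g-1.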

Compound 3, intrinsic clearance in microsomes: 30 mL.min-1.g-1
For compound 3 the middle estimate is 1.3-fold (0.12 log units) above the measured one; the measured number falls inside the stated range.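

In this assay, a second, different group at this place on the aromatic ring also gives a large step: an at least 13-fold lower number from compound 1 to compound 3 (1.12 log units; beyond the scatter). Compound 2 and compound 3 cannot be told apart, as the step lies within the scatter: a 1.3-fold higher number from compound 2 to compound 3 (0.12 log units; within the scatter). A sulfamoyl group, with no ring, therefore serves as well here as the larger group of compound 2 with its three-membered ring of carbon.

On these data alone, the full size of the step from hydrogen stays open because compound 1 gives a limit, not a number: the limit of > 399 mL.min-1.g-1 in this assay, at which 1 of the 3 values shown sits. As far as these compounds go, whether a simpler group here, such as an amine or a carboxylic acid, would give a similar number is also open.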